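The source may hold more compounds than are shown below. What is called first, only, known or untested is meant among the compounds shown, and "the series" means these compounds.

Measured so far:
Compound 1 `COc1cc(/C=C/c2ccc(C3=C(c4ccc(O)cc4)C4CC(S(=O)(=O)Oc5ccccc5)C3O4)cc2)cc(OC)c1`: in a functional assay on MCF7 cells (Homo sapiens) for antiproliferative activity, read by MTT assay, with a stated time of 72 h (on this read-out lower numbers stand for stronger inhibition and higher numbers for weaker inhibition), compound 1 gives > 100000 nM, which is a limit of the assay rather than a number.
Compound 2 `O=S(=O)(Oc1ccccc1)C1CC2OC1C(c1ccc(/C=C/c3cc(O)cc(O)c3)cc1)=C2c1ccc(O)cc1`: in this assay compound 2 gives 20100 nM.
Compound 3 `COc1cc(/C=C/c2cccc(OS(=O)(=O)C3CC4OC3C(c3ccc(O)cc3)=C4c3ccc(O)cc3)c2)cc(OC)c1`: in this assay compound 3 gives 11500 nM.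

Compound 1 and compound 2 share a core and differ in one place: 3,5-dihydroxyphenyl in place of 3,5-dimethoxyphenyl on a double-bonded chain carbon bound to a double-bonded chain carbon. That change gave an at least 4.9-fold lower number from compound 1 to compound 2 (0.69 log units; beyond the scatter), a step counted from the limit of > 100000 nM in this assay, at which 1 of the 3 values shown sits. Compound 3 is built on a different arrangement; how the core of compound 3 differs from the core of compound 1 is not broken down here. The values of compound 2 and compound 3 lie within the usual scatter of each other, so neither can be called stronger than the other.

Compound 4 `O=S(=O)(Oc1cccc(/C=C/c2cc(O)cc(O)c2)c1)C1CC2OC1C(c1ccc(O)cc1)=C2c1ccc(O)cc1` has not yet been measured. It differs from compound 3 by 3,5-dihydroxyphenyl in place of 3,5-dimethoxyphenyl on a double-bonded chain carbon bound to a double-bonded chain carbon, the same change, in the same place, that turns compound 1 into compound 2. The expectation for compound 4 rests on that one measured step, an at least 4.9-fold lower number from compound 1 to compound 2 (0.69 log units; beyond the scatter), and on the starting value of compound 3, 11500 nM. The expected step from compound 3 to compound 4 is a 2.9-fold lower number from compound 3 to compound 4 (0.46 log units; beyond the scatter), set somewhat smaller than the measured step; a single example of the change is thin ground. For compound 4 the estimated result in this assay is therefore 4000 nM, expected to fall between 1200 nM and 13000 nM.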

Compound 4, half-maximal inhibitory concentration: 17800 nM
Compound 4: middle estimate off by 4.5-fold (0.65 log units), on the low side; measured number outside the range, above it.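

In this assay, putting 3,5-dihydroxyphenyl in place of 3,5-dimethoxyphenyl on the second core gives a 1.5-fold higher number from compound 3 to compound 4 (0.19 log units; within the scatter), so these two compounds cannot be told apart in this assay. This means that the gain seen on the first core did not carry over to the second, and the effect of this change cannot be treated as a rule that holds across the series: the same change on two cores in this assay, an at least 4.9-fold lower number (0.69 log units; beyond the scatter) from compound 1 to compound 2 and a 1.5-fold higher number (0.19 log units; within the scatter) from compound 3 to compound 4, at least 7.7-fold (0.88 log units) apart, beyond the scatter of two such steps

Compound 1 gives > 100000 nM, which is a limit of the assay and not a number, so the earlier step has no exact size, and the two examples show that the outcome can depend on the core without showing why.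

Going by these compounds alone, with only two cores to compare, it stays open how the same change would behave on a further core. Going by these compounds, it is also open what this assay would show for a phenyl ring carrying an amine or a carboxylic acid in place of the two hydroxyl groups of the 3,5-dihydroxyphenyl group.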